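Chloro for methoxy on the methylsulfonyl core

The source may hold more compounds than are shown below. What is called first, only, known or untested is meant among the compounds shown, and "the series" means these compounds.

Compound 1 `COc1ccc(S(C)(=O)=O)c(NCC2=NCCN2)c1` gives 14.1 nM in a functional assay for agonist activity at Alpha-1A adrenergic receptor (Homo sapiens) (on this read-out lower numbers stand for an effect already at smaller amounts and higher numbers for an effect only at larger amounts of compound), and holds the highest of the three numbers recorded. Compound 2 `CSc1c(F)cccc1NCC1=NCCN1` gives 7.76 nM in this assay, a number within the scatter of compound 1. For the measured compounds named here, compound 3 `COc1ccc(SC)c(NCC2=NCCN2)c1` gives 1.59 nM in this assay, and the step of an 8.9-fold lower number from compound 1 to compound 3 (0.95 log units; beyond the scatter) is the only one-place change measured so far; it concerns the sulfur group, not the methoxy group.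

Compound 4 `CS(=O)(=O)c1ccc(Cl)cc1NCC1=NCCN1` is compound 1 with chloro in place of methoxy on an aromatic carbon. Going by the values given here, no measured step touches this group: compound 2 differs from compound 1 in two places at once and its numbers with compound 1 show no more than that the two sit within the scatter of each other. Among the compounds with values here, the one measured step, from compound 1 to compound 3, is beyond the scatter but alters a different group, so it gives no guide to the size or direction of the present change. For compound 4 no step beyond the scatter is therefore expected in this assay; the estimate is kept near compound 1 with a wide range. Compound 4 is expected to give 12 nM in this assay, from 4 nM to 40 nM. The expected step is a 1.2-fold lower number from compound 1 to compound 4 (0.07 log units; within the scatter).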

Compound 4, half-maximal effective concentration: 2.82 nM
For compound 4 the middle estimate is 4.3-fold (0.63 log units) above the measured one, outside the stated range (below it).
By their numbers in this assay, from the lowest: compounds 3 and 4 (each within the scatter of the next); then compounds 2 and 1 (each within the scatter of the next).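

In this assay, for the compounds shown here, the aromatic carbon para to the methylsulfonyl group proves sensitive to substitution: chloro in place of methoxy gives a 5.0-fold lower number from compound 1 to compound 4 (0.70 log units; beyond the scatter), the first step beyond the scatter seen at this position. Together with an 8.9-fold lower number from compound 1 to compound 3 (0.95 log units; beyond the scatter), this gives the core of compound 1 two one-place changes, one at the sulfur group and one at this carbon, and both lead to a lower number, so methoxy is not required for a low number on the methylsulfonyl core. Nothing available bears on the reason for this step, so it stands as an observation only.

The compounds shown leave open whether chloro and methylsulfanyl together on the shared core would combine the two steps or whether one would mask the other. They also leave open whether the lower number follows from chloro itself or simply from the loss of methoxy, a question that a bromo, methyl or ethoxy group at the same carbon could help to separate.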